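Extending the side group of compound 2

The source may report more compounds than this note shows. Statements on the series, on what has been measured and on what is new or still open speak of the compounds shown alone.

Measured in an assay on CHO cells for displacement of a labelled ligand from 5-hydroxytryptamine receptor 1D (Homo sapiens); a higher number here means a weaker inhibitor, a lower number a stronger inhibitor:
Compound 1 `c1ccc(CC2CCN(CCCc3c[nH]c4ccc(-n5cnnc5)cc34)CC2)cc1`: 0.35 nM
Compound 2 `FC1(Cc2ccccc2)CCN(CCCc2c[nH]c3ccc(-n4cnnc4)cc23)CC1`: 1 nM

Compound 2 stands as the higher of the two numbers. Among the compounds with values here, the single measured step, a 2.9-fold higher number from compound 1 to compound 2 (0.46 log units; beyond the scatter), concerns fluoro in place of hydrogen on a saturated ring carbon. Compound 3 `Fc1cccc(CCC2(F)CCN(CCCc3c[nH]c4ccc(-n5cnnc5)cc34)CC2)c1` is reached by a different change: 3-fluorobenzyl in place of phenyl on a saturated chain carbon bound to a saturated ring carbon. Within the data shown here, no measured step touches that part of the shared core, so there is nothing to scale from. The step is therefore expected to stay within the scatter, a 1.2-fold higher number from compound 2 to compound 3 (0.08 log units; within the scatter). Compound 3 is estimated at 1.2 nM, within a range from 0.4 nM to 4 nM.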

Compound 3, half-maximal inhibitory concentration: 0.75 nM
The estimate for compound 3 lay 1.6-fold (0.20 log units) above the measured number, within the range that was stated.
By their numbers in this assay, from the lowest: compound 1; then compounds 3 and 2 (each within the scatter of the next).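

Going from benzyl to 2-(3-fluorophenyl)ethyl gives a 1.3-fold lower number from compound 2 to compound 3 (0.12 log units; within the scatter) and so shows that this side group can be lengthened and carry a fluorine on its phenyl ring with no shift that stands clear of the scatter. The earlier step involved only the saturated ring carbon and did not address this outer part of the molecule. No supporting measurement offers an explanation for this result.

From the compounds shown here alone, this step joins a longer chain and a ring fluorine, so the contribution of each stays open. Also open, going by these compounds, is how an amine or a carboxylic acid on that phenyl ring would read.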